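Halogen swap at the aryl terminus of the dienone series

The source may report more compounds than this note shows. Statements on the series, on what has been measured and on what is new or still open speak of the compounds shown alone.

Working notes on a small set of dienones built on one shared core. Compound 1 `CC1=C(/C=C/C(=O)/C=C/c2ccccc2)C(C)(C)CCC1` carries an unsubstituted phenyl ring; in a functional assay on HeLa cells (Homo sapiens) for cytotoxicity, read by sulforhodamine B assay, with a stated time of 48 h (a higher number here means a weaker inhibitor, a lower number a stronger inhibitor), compound 1 gives 70200 nM. Compound 2 `CC1=C(/C=C/C(=O)/C=C/c2ccc(Cl)cc2)C(C)(C)CCC1` carries chloro on that ring, and in this assay compound 2 gives 33200 nM. Compound 3 `CC1=C(/C=C/C(=O)/C=C/c2ccc(Br)cc2)C(C)(C)CCC1` carries bromo in the same place, and in this assay compound 3 gives 88800 nM. Compound 3 holds the highest number of the three, but its footing is uneven: the step of a 1.3-fold higher number from compound 1 to compound 3 (0.10 log units; within the scatter) lies within the scatter, whereas a 2.7-fold higher number from compound 2 to compound 3 (0.43 log units; beyond the scatter) lies beyond it, as does a 2.1-fold lower number from compound 1 to compound 2 (0.33 log units; beyond the scatter).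

Compound 4 `CC1=C(/C=C/C(=O)/C=C/c2ccc(F)cc2)C(C)(C)CCC1` differs from compound 3 by fluoro in place of bromo on an aromatic carbon. Among the compounds with values here, no measured step exchanges fluoro for anything, so the only bearing comes from the three halogen-related steps, which are all modest and point in opposite directions. On that basis a step of modest size in either direction is plausible, and a return toward the number of compound 1 is the most defensible reading. Compound 4 is therefore expected to give about 60000 nM in this assay, with a range of 25000 nM to 140000 nM. The expected step of a 1.5-fold lower number from compound 3 to compound 4 (0.17 log units; within the scatter) would stay within the scatter.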

Compound 4, half-maximal inhibitory concentration: 32200 nM
Compound 4: middle estimate off by 1.9-fold (0.27 log units), on the high side; measured number inside the range.
By their numbers in this assay, from the lowest: compounds 4 and 2 (each within the scatter of the next); then compounds 1 and 3 (each within the scatter of the next).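

In this assay, the exchange at this position gives a 2.8-fold lower number from compound 3 to compound 4 (0.44 log units; beyond the scatter), so the gap first seen between chloro and bromo now appears with a second halogen, and bromo stands apart from both fluoro and chloro. Fluoro and chloro cannot be separated here, with a 1.0-fold lower number from compound 2 to compound 4 (0.01 log units; within the scatter), and fluoro also gives a 2.2-fold lower number from compound 1 to compound 4 (0.34 log units; beyond the scatter), a step in the same direction as the one for chloro. Two of the three halogens therefore lower the number relative to the unsubstituted phenyl ring, while compound 3 goes against this pattern, with a 1.3-fold higher number from compound 1 to compound 3 (0.10 log units; within the scatter). No available evidence accounts for the different behaviour of bromo in this series.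

The compounds shown leave open whether the lower numbers extend beyond fluoro and chloro to a different kind of group on the same aromatic carbon, such as methoxy, nitrile or an amine. They also leave open whether the separation of bromo from the other two halogens would hold with iodo at this position or with any of these halogens on another aromatic carbon of the ring.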